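Moving the fluorine on the carbamate's phenyl ring

A few compounds are considered here, and "the series" means these few. Any claim that something is new, unique, unknown or untested is made for them only; others in the source may bear on it.

Measured so far:
compound 1 `CC(C)=CCC/C(C)=C/CC1Cc2c(OCC=C(C)C)cc(=O)n(CCCO)c2CC1(C)C` gives 30.3%
compound 2 `COc1ccccc1NC(=O)Oc1cc(=O)n(CCCO)c2c1CC(C/C=C(\C)CCC=C(C)C)C(C)(C)C2` gives 53%
compound 3 `CC(C)=CCC/C(C)=C/CC1Cc2c(OC(=O)Nc3ccc(F)cc3)cc(=O)n(CCCO)c2CC1(C)C` gives 43.9%

All three values come from a functional assay on PANC-1 cells (Homo sapiens) for inhibition, read by MTT assay, with a stated time of 24 h, tested at 10 uM; on this read-out lower numbers stand for less inhibition and higher numbers for more inhibition at the one concentration tested (going by the name of the read-out). Compound 3 stands second highest of the three numbers: compound 2 lies a number 9.1 percentage points lower from compound 2 to compound 3 (within the scatter), a difference within the scatter, while compound 1 lies a number 13.6 percentage points higher from compound 1 to compound 3 (beyond the scatter), which is beyond the scatter. The two carbamates, compound 2 and compound 3, thus sit together above compound 1.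

Compound 4 `CC(C)=CCC/C(C)=C/CC1Cc2c(OC(=O)Nc3cccc(F)c3)cc(=O)n(CCCO)c2CC1(C)C` is not yet measured. Its difference from compound 3 is 3-fluorophenyl in place of 4-fluorophenyl on an amide-type nitrogen. Among the compounds with values here, no measured step changes the position of a substituent on this phenyl ring. The closest comparison is the swap of 2-methoxyphenyl for 4-fluorophenyl from compound 2 to compound 3, which moved this assay by a number 9.1 percentage points lower from compound 2 to compound 3 (within the scatter), within the scatter. The larger steps, a number 22.7 percentage points higher from compound 1 to compound 2 (beyond the scatter) and a number 13.6 percentage points higher from compound 1 to compound 3 (beyond the scatter), concern the exchange of the whole 3-methylbut-2-en-1-yl group for a carbamoyl group and do not apply here, since compound 4 keeps the carbamate. I therefore expect no step beyond the scatter in this assay, with compound 4 at about 44%, ranging from 30% to 58%, which means an expected step of a number 0.1 percentage points higher from compound 3 to compound 4 (within the scatter).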

Compound 4, a percentage reported as inhibition, at one concentration (the size of the read-out at that concentration, not a potency): 52.3%
Estimate against measurement, compound 4: 8.3 percentage points below; measured number inside the range.
By their numbers in this assay, from the lowest: compound 1; then compounds 3, 4 and 2 (each within the scatter of the next).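

In this assay, within the data shown here, the change from 4-fluorophenyl to 3-fluorophenyl on the amide-type nitrogen is the first comparison in which only the position of a substituent on this ring differs, and it gives a number 8.4 percentage points higher from compound 3 to compound 4 (within the scatter), so this read-out does not separate the two arrangements of the same atoms. Compound 4 also cannot be told apart from the compound bearing 2-methoxyphenyl on that nitrogen, with a number 0.7 percentage points lower from compound 2 to compound 4 (within the scatter), so a different substituent on the ring makes no difference that can be read here either. The exchange of 3-methylbut-2-en-1-yl on the aromatic oxygen for (3-fluorophenyl)carbamoyl gives a number 22 percentage points higher from compound 1 to compound 4 (beyond the scatter), which makes this the third carbamate to lie beyond the scatter from compound 1, with no exception among the compounds shown.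

Nothing here gives a measured reason for these numbers. Still open, from the compounds shown here alone, is whether a phenyl ring carrying an amine or a carboxylic acid in place of the fluorine would stand apart from these carbamates, and a single tested concentration cannot show how their potencies compare.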